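This account rests on a few compounds, and the source may have more. Where it says the series, first, only, none or still open, it means among the compounds named here.

Within the data shown here, compound 2 `C#CCN(CCCOc1ccc2ccc(=O)oc2c1)Cc1ccc(F)c(F)c1` gives 49200 nM in an ADME assay on isolated protein for inhibition of Amine oxidase [flavin-containing] A (Homo sapiens), read by fluorescence and Amplex Red, with stated times of 15 min and 20 min (a higher number here means a weaker inhibitor, a lower number a stronger inhibitor), the second highest of the three numbers so far. Compound 1 `C#CCN(C)CCCOc1ccc2ccc(=O)oc2c1` gives 36900 nM and compound 3 `C#CCN(CCCCOc1ccc2ccc(=O)oc2c1)Cc1ccc(F)c(F)c1` gives 93200 nM in this assay, both within the scatter of compound 2. Among the measured compounds shown here, the single measured step, a 1.3-fold higher number from compound 1 to compound 2 (0.12 log units; within the scatter), lies within the scatter. Compound 4 `C#CCN(CCCOc1ccc2ccc(=O)oc2c1)Cc1ccc(C(C)C)cc1` differs from compound 2 by 4-isopropylphenyl in place of 3,4-difluorophenyl on a saturated chain carbon bound to an amine nitrogen. For the measured compounds named here, no measured step exchanges one aryl group for another, so only the small effect of introducing an aryl group in the step from compound 1 to compound 2 is a guide, and no step beyond the scatter is expected in this assay. The expected step of a 1.0-fold higher number from compound 2 to compound 4 (0.01 log units; within the scatter) is within the scatter. Compound 4 is therefore estimated at 50000 nM in this assay, with a range from 15000 nM to 150000 nM.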

Compound 4, half-maximal inhibitory concentration: 77400 nM
Compound 4: middle estimate off by 1.5-fold (0.19 log units), on the low side, and the stated range covers the measured number.
By their numbers in this assay, from the lowest: compounds 1, 2, 4 and 3 (each within the scatter of the next, the first and the last beyond it).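

In this assay the exchange of one aryl group for another on a saturated chain carbon bound to an amine nitrogen (a 1.6-fold higher number from compound 2 to compound 4 (0.20 log units; within the scatter)) does not separate 4-isopropylphenyl from 3,4-difluorophenyl. Measured against hydrogen at the same place, 4-isopropylphenyl gives the only listed step beyond the scatter (a 2.1-fold higher number from compound 1 to compound 4 (0.32 log units; beyond the scatter)), and that step is modest. No measurement on hand bears on the reason for either step. As far as these compounds go, how a pyridine ring or a carboxylic acid would read at this place stays open.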